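Bromo to chloro swap on a bicyclic core, growth inhibition

The compounds below may be only part of what the source reports. "The series", "measured", "known", "first", "only" and "open" are said of these compounds alone.

Measured so far in a functional assay on MCF7 cells (Homo sapiens) for cytotoxicity, read by sulforhodamine B assay, with a stated time of 48 h; on this read-out lower numbers stand for stronger inhibition of growth and higher numbers for weaker inhibition of growth:
- compound 1, `CCN(CC)CN1C(=O)/C(=N\c2nc3ccc(C)cc3s2)c2c(Br)cccc21`, gives 30200 nM
- compound 2, `CCN(CC)CN1C(=O)C(=O)c2c(Br)cccc21`, gives 20200 nM
- compound 3, `CCN(CC)CN1C(=O)C(=O)c2c(Cl)cccc21`, gives 34100 nM

Compounds 2 and 3 share a core and differ in one place only: chloro in place of bromo on an aromatic carbon. In this assay this gave a 1.7-fold higher number from compound 2 to compound 3 (0.23 log units; within the scatter), so the swap left the read-out essentially where it was.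

Compound 1 carries a different core from compound 2; the difference between the two cores is not broken down here. Its value in this assay sits close to those of compounds 2 and 3, and none of the three is set apart from the others by more than the usual scatter.

Compound 4, `CCN(CC)CN1C(=O)/C(=N\c2nc3ccc(C)cc3s2)c2c(Cl)cccc21`, has not yet been measured. It stands to compound 1 as compound 3 stands to compound 2: chloro in place of bromo on an aromatic carbon. The place of the change is described in the same words for both pairs, so this is the same change on the other core.

Going by the values given here, the expectation for compound 4 in this assay rests on the one precedent, compound 2 to compound 3, where the step was a 1.7-fold higher number from compound 2 to compound 3 (0.23 log units; within the scatter); a step of about the same size, a 1.3-fold higher number from compound 1 to compound 4 (0.12 log units; within the scatter), is expected from compound 1 to compound 4. Among the compounds with values here, with the single precedent lying inside the scatter, a wide range is kept. Compound 4 is thus estimated at 40000 nM in this assay, expected to fall between 18000 nM and 85000 nM.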

Compound 4, concentration for 50% growth inhibition: 19200 nM
Estimate against measurement, compound 4: 2.1-fold (0.32 log units) above; the range from low to high includes it.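

In this assay, chloro in place of bromo on an aromatic carbon gives a 1.6-fold lower number from compound 1 to compound 4 (0.20 log units; within the scatter), so on the core of compound 1 the swap leaves the read-out essentially where it was, as it did on the core of compound 2. Going by these compounds alone, although the two steps are printed with opposite signs, the gap between them gives no ground for treating the two cores differently: the same change on two cores in this assay, a 1.7-fold higher number (0.23 log units; within the scatter) from compound 2 to compound 3 and a 1.6-fold lower number (0.20 log units; within the scatter) from compound 1 to compound 4, 2.7-fold (0.42 log units) apart, within the scatter of two such steps This shows that, in this pair of cores, the change carries over as a step that stays inside the scatter each time; it does not show a direction or size of effect for the change on either core, and with only two pairs it gives no rule for any other core.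

Open is how the read-out in this assay would respond to a fluoro, iodo or methoxy group on the same aromatic carbon, where only bromo and chloro appear among the compounds shown. Also open, going by these compounds, is whether either core would move beyond the scatter with a cyclic amine such as morpholine in place of the diethylamino group.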